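Inhibition in rats: ester and ether changes on a shared core

The source may hold more compounds than are shown below. What is called first, only, known or untested is meant among the compounds shown, and "the series" means these compounds.

Measured compounds:
Compound 1, `O=C(O)c1cnc(-c2ccccc2OCc2ccccc2)[nH]c1=O`: 5 mg/kg
Compound 2, `CSc1ccccc1-c1ncc(C(=O)O)c(=O)[nH]1`: > 20 mg/kg
Compound 3, `CCOC(=O)c1cnc(-c2ccccc2OCc2ccccc2)[nH]c1=O`: > 5 mg/kg

Of the compounds shown here, three have been tested in a functional assay on the whole organism (strain Sprague-Dawley) for inhibition, with Rattus norvegicus as the target, with a stated time of 10 min; a lower number here means that less compound is needed, a higher number that more compound is needed for the effect. In this assay compound 1 gives 5 mg/kg. For compound 2 the assay reports only a limit, > 20 mg/kg. For compound 3 the result is likewise only a limit, > 5 mg/kg.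

Compound 1 and compound 2 differ by methylsulfanyl in place of benzyloxy on an aromatic carbon. This change brings an at least 4.0-fold higher number from compound 1 to compound 2 (0.60 log units; beyond the scatter), and the number for compound 2 is a limit (the limit of > 20 mg/kg in this assay, at which 1 of the 3 values shown sits). Compound 1 and compound 3 differ by ethyl in place of hydrogen on an oxygen next to a carbonyl group; here the result is a number no lower from compound 1 to compound 3 (the limit leaves the size open), the number for compound 3 being a limit (the limit of > 5 mg/kg in this assay, at which 1 of the 3 values shown sits).

Compound 4, `CCOC(=O)c1cnc(-c2ccccc2SC)[nH]c1=O`, has not been measured in this assay. For the measured compounds named here, it differs from compound 3 by methylsulfanyl in place of benzyloxy on an aromatic carbon, which is the same change as the one from compound 1 to compound 2, made on the ester core instead of the acid core of compound 1.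

Since the step from compound 1 to compound 2 gave at least a modest rise in the number needed, and compound 3 already sits at a limit, compound 4 is expected to show a step that the limit leaves unreadable from compound 3 to compound 4 in this assay, resting on an at least 4.0-fold higher number from compound 1 to compound 2 (0.60 log units; beyond the scatter) and on compound 3 giving > 5 mg/kg. It is therefore expected that compound 4 will need about 40 mg/kg in this assay, most likely between 15 mg/kg and 150 mg/kg, and it is expected that the assay will in all likelihood again report only a limit.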

Compound 4, dose for 50% inhibition: > 25 mg/kg
Compound 4: only a limit was reported; the forecaster's own chance of this, stated with the estimate: 85%; the middle value does not contradict the limit.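

In this assay compound 4 gives only a limit, > 25 mg/kg. The results for compound 2 and compound 3 are limits as well, so the steps from each of them to compound 4 cannot be read. The compounds shown leave open how much of compound 4 is actually needed, and whether methylsulfanyl in place of benzyloxy raises the number on the core of compound 3 as it does on the core of compound 1.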